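Chlorophenyl to bromophenyl exchange: notes on compound 3

The compounds below may be only part of what the source reports. "The series", "measured", "known", "first", "only" and "open" are said of these compounds alone.

Values in a functional assay on HT-1080 cells (Homo sapiens) for cytotoxicity, read by MTT assay, with a stated time of 72 h; on this read-out lower numbers stand for stronger inhibition and higher numbers for weaker inhibition:
- compound 1 `COc1ccc(/C=C2\CCC/C(=C\c3cccc(Cl)c3)C2=O)cc1OC`: 4900 nM
- compound 2 `COc1ccc(/C=C2\CCC/C(=C\c3ccc(Cl)cc3)C2=O)cc1OC`: 4800 nM
- compound 3 `COc1ccc(/C=C2\CCC/C(=C\c3cccc(Br)c3)C2=O)cc1OC`: not yet measured

Within the data shown here, compound 2 stands at 4800 nM, and compound 1, the only other measured compound, lies within the scatter of it. The next change is 3-bromophenyl in place of 4-chlorophenyl on a double-bonded chain carbon bound to a double-bonded ring carbon, with 3-bromophenyl in place of 4-chlorophenyl on a double-bonded chain carbon bound to a double-bonded ring carbon.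

Among the measured compounds shown here, only one measured step bears on this change. Between compound 1 and compound 2, the exchange of 3-chlorophenyl for 4-chlorophenyl gives a 1.0-fold lower number from compound 1 to compound 2 (0.01 log units; within the scatter), which is within the scatter. For the measured compounds named here, no measured step exchanges chlorine for bromine, so that part of the change remains untested and the range is kept wide. On this limited evidence, no step beyond the scatter is expected in this assay, and no direction can be assigned. The expected step is a 1.1-fold lower number from compound 2 to compound 3 (0.03 log units; within the scatter). For compound 3 the estimated value is 4500 nM, with an expected range from 2300 nM to 9000 nM.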

Compound 3, half-maximal inhibitory concentration: 5200 nM
Compound 3: middle estimate off by 1.2-fold (0.06 log units), on the low side; measured number inside the range.
By their numbers in this assay, from the lowest: compounds 2, 1 and 3 (each within the scatter of the next).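

In this assay, bromo in place of chloro on an aromatic carbon gives a 1.1-fold higher number from compound 1 to compound 3 (0.03 log units; within the scatter), so this exchange of halogen, with the ring otherwise unchanged, does not separate the two compounds. The change from 4-chlorophenyl to 3-bromophenyl on the double-bonded chain carbon bound to a double-bonded ring carbon gives a 1.1-fold higher number from compound 2 to compound 3 (0.03 log units; within the scatter); together with the earlier comparison of 3-chlorophenyl and 4-chlorophenyl, this means that neither of the two halogens shown nor either of the two substitution patterns shown sets any of the three compounds apart at this place. Nothing available accounts for how closely the three compounds agree.

From the compounds shown here alone, all three compounds carry a halogen on this phenyl ring, so it remains open whether a group of another kind there, such as an amine or a carboxylic acid, would give a step beyond the scatter. Also open, going by these compounds, is whether 4-bromophenyl at the same place would stay within the scatter of compound 2 and compound 3.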